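The compounds below may be only part of what the source reports. "The series", "measured", "known", "first", "only" and "open" are said of these compounds alone.

Compound 1 `CC(=O)OC1C(CN=[N+]=[N-])OC(n2c(Cl)nc3cc(Cl)c(Cl)cc32)C1OC(C)=O` and compound 2 `CSCC1OC(n2c(Cl)nc3cc(Cl)c(Cl)cc32)C(OC(C)=O)C1OC(C)=O` share one core and differ in a single spot: methylsulfanyl in place of azido on a saturated chain carbon bound to a saturated ring carbon. In a functional assay on HFF cells (Homo sapiens) for cytotoxicity (a lower number here means a stronger inhibitor, a higher number a weaker inhibitor), compound 1 gives 32000 nM. Compound 2 gives 32000 nM in this assay, so the step reads no change at the digits printed from compound 1 to compound 2 (within the scatter). Compound 3 `[N-]=[N+]=NC[C@H]1OC(n2c(Cl)nc3cc(Cl)c(Cl)cc32)[C@H](O)[C@@H]1O` also carries an azido group, but on a core whose difference from the core of compound 1 is not broken down here. In this assay compound 3 gives 32000 nM. Compound 4 `CSC[C@H]1OC(n2c(Cl)nc3cc(Cl)c(Cl)cc32)[C@H](O)[C@@H]1O` arises from compound 3 through the same change: methylsulfanyl in place of azido on a saturated chain carbon bound to a saturated ring carbon. The expectation for compound 4 rests on the earlier step of no change at the digits printed from compound 1 to compound 2 (within the scatter), which stayed within the scatter. The step is therefore expected to read no change at the digits printed from compound 3 to compound 4 (within the scatter). Compound 4 is estimated at 32000 nM, with a likely range from 16000 nM to 64000 nM.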

Compound 4, half-maximal inhibitory concentration: 32000 nM
Compound 4: middle estimate and measured number agree at the digits printed, and the stated range covers the measured number.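

In this assay, putting methylsulfanyl in place of azido gives no change at the digits printed from compound 3 to compound 4 (within the scatter). Set beside the earlier step, the same change gives matching results on the two cores: the same change on two cores in this assay, no change at the digits printed (within the scatter) from compound 1 to compound 2 and no change at the digits printed (within the scatter) from compound 3 to compound 4, 1.0-fold (0.00 log units) apart, within the scatter of two such steps This shows that the swap leaves the value in place on these two cores, but it does not show that the same would hold on any other core or in any other assay, and since neither step moved the value, it cannot say whether a change that does shift the number would carry over.

The compounds shown leave open what other groups would do on this saturated chain carbon, such as an amine, a carboxylic acid or a longer chain ending in sulfur.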